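From a tert-butyl piperazine to a methyl piperazine

This account rests on a few compounds, and the source may have more. Where it says the series, first, only, none or still open, it means among the compounds named here.

In a physicochemical assay for solubility, read by HPLC, using the shake flask method, in phosphate buffer, measured as kinetic solubility, with a stated time of 20 h, at pH 6.5 (on this read-out higher numbers stand for higher solubility and lower numbers for lower solubility), compound 3 (`CC(C)(C)N1CCN(c2ccc(Nc3nc4cnc(Nc5cccc(C(F)(F)F)c5)cc4[nH]3)nc2)CC1`) gives 50000 nM and stands within the scatter of compound 1 (`Fc1ccc(Nc2cc3[nH]c(Nc4cc(N5CCNCC5)ccn4)nc3cn2)cc1C(F)(F)F`) at 95000 nM in the same test. Compound 2 (`Fc1ccc(Nc2cc3[nH]c(Nc4ccc(N5CCN(C6CC6)CC5)cn4)nc3cn2)cc1C(F)(F)F`) gives 5000 nM and lies beyond the scatter, lower than compound 3. Compound 4 (`C[C@H]1CN(c2ccc(Nc3nc4cnc(Nc5cccc(C(F)(F)F)c5)cc4[nH]3)nc2)CCN1`) carries 3-methylpiperazin-1-yl in place of 4-(tert-butyl)piperazin-1-yl on an aromatic carbon. Among the measured compounds shown here, no measured pair shows this change alone. For the measured compounds named here, the one guide is compound 1 at 95000 nM as the only measured compound whose piperazine bears no substituent, though it differs elsewhere too. A small upward move in this assay is therefore expected, estimated as a 1.4-fold higher number from compound 3 to compound 4 (0.15 log units; within the scatter) and not beyond the scatter. For compound 4 the estimated value is 70000 nM with an expected range from 25000 nM to 150000 nM overall.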

Compound 4, solubility: 180000 nM
Beside the measured number, compound 4's estimate is 2.6-fold (0.41 log units) below it, outside the stated range (above it).
By their numbers in this assay, from the lowest: compound 2; then compounds 3, 1 and 4 (each within the scatter of the next, the first and the last beyond it).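

In this assay, among the compounds shown here, replacing 4-(tert-butyl)piperazin-1-yl with 3-methylpiperazin-1-yl on an aromatic carbon gives a 3.6-fold higher number from compound 3 to compound 4 (0.56 log units; beyond the scatter), the first step here with a single change and the shared core held constant. For the compounds shown here, the change alone therefore moves the reading beyond the scatter at this position, which the earlier compounds, differing in more than one place, could not show. Nothing measured here accounts for the step. The compounds shown leave open whether the step follows from losing the tert-butyl group or from the methyl group and its stereocentre, and how a morpholine would read at this position.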